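Replacing methylsulfonyl with 1H-imidazol-1-yl at the assay limit

This account rests on a few compounds, and the source may have more. Where it says the series, first, only, none or still open, it means among the compounds named here.

In a functional assay for inhibition, with Rattus norvegicus as the target (a lower number here means a stronger inhibitor, a higher number a weaker inhibitor), compound 1 (`CC(/N=c1\c(O)c(O)\c1=N/c1ccc(S(N)(=O)=O)cc1)C(C)(C)C`) gives > 30000 nM, which is a limit and not a number. Compound 2 (`CC(/N=c1\c(O)c(O)\c1=N/c1ccc(S(C)(=O)=O)cc1)C(C)(C)C`) gives > 30000 nM, also a limit. Compound 3 (`CC(/N=c1\c(O)c(O)\c1=N/c1ccc(-n2ccnc2)cc1)C(C)(C)C`) carries 1H-imidazol-1-yl in place of methylsulfonyl on an aromatic carbon, para to a large group: 1H-imidazol-1-yl in place of methylsulfonyl on an aromatic carbon. Among the compounds with values here, the only measured step bearing on this, a step that the two limits leave unreadable from compound 1 to compound 2, offers no size to carry over, and the limit of > 30000 nM in this assay, at which 2 of the 2 values shown sit, describes the series so far. No readable change in either direction is expected, and the estimated step is an at least 1.5-fold lower number from compound 2 to compound 3 (0.17 log units; that floor lies within the scatter). For compound 3 the expected value is 20000 nM, with an estimated range of 3000 nM to 30000 nM.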

Compound 3, half-maximal inhibitory concentration: > 30000 nM
Compound 3 ended at the assay's limit (the forecaster's own chance of this, stated with the estimate: 60%); at least 1.5-fold (0.17 log units) between middle value and limit.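

No step can be read among compound 1, compound 2 and compound 3, since all three stand at a limit and not a number: the limit of > 30000 nM in this assay, at which 3 of the 3 values shown sit.

Going by these compounds, whether sulfamoyl, methylsulfonyl and 1H-imidazol-1-yl differ at all in inhibition stays open.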